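Aryl swap on the imidazole carbon of the compound 2 series

The source may hold more compounds than are shown below. What is called first, only, known or untested is meant among the compounds shown, and "the series" means these compounds.

Measured so far:
- compound 1, `CCn1c(-c2ccccc2)nc2c(NC3CCC3)ncnc21`: 84 nM
- compound 2, `Cn1c(-c2cccc(Cl)c2)nc2c(NC3CCCC3)ncnc21`: 514 nM
- compound 3, `CCn1c(-c2ccccc2)nc2c(NC3CCCC3)ncnc21`: 354 nM

All three numbers come from an assay on CHO cells for displacement of a labelled ligand from adenosine receptor A3 (Homo sapiens), read by scintillation counting, with a stated time of 3 h; on this read-out higher numbers stand for weaker inhibition and lower numbers for stronger inhibition. Compound 2 gives the highest number of the three; its nearest neighbour is compound 3, whose value sits within the scatter of it, while compound 1 lies clearly lower. Among the compounds with values here, the one single-point step in hand is a 4.2-fold higher number from compound 1 to compound 3 (0.62 log units; beyond the scatter), which concerns the amine substituent, not the aryl group.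

The step to compound 4, `Cc1ccccc1-c1nc2c(NC3CCCC3)ncnc2n1C`, is 2-methylphenyl in place of 3-chlorophenyl on an aromatic carbon. Within the data shown here, no measured pair isolates a change on this aryl ring: compound 2 and compound 3 differ in two places at once, and their values are within the scatter of each other, so they give no lever on the chlorine alone. Among the measured compounds shown here, there is thus no precedent for the direction of this change, and the expectation is of no step beyond the scatter in this assay , i.e. a 1.0-fold lower number from compound 2 to compound 4 (0.01 log units; within the scatter) is expected to be small.

Compound 4 is accordingly estimated at 500 nM, with a range from 150 nM to 1700 nM.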

Compound 4, inhibition constant: 3000 nM
Compound 4: middle estimate off by 6.0-fold (0.78 log units), on the low side, and the stated range ends below it.
By their numbers in this assay, from the lowest: compound 1; then compounds 3 and 2 (each within the scatter of the next); then compound 4.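

Within this assay, this aromatic carbon proves sensitive to the choice of aryl group: with 2-methylphenyl in place of 3-chlorophenyl, the series shows a 5.8-fold higher number from compound 2 to compound 4 (0.77 log units; beyond the scatter). Within the data shown here, this gives the first reading of a change on the aryl group alone, and it joins the amine change, a 4.2-fold higher number from compound 1 to compound 3 (0.62 log units; beyond the scatter), as a second single-place step beyond the scatter. No available evidence bears on what lies behind the step.

The step from compound 2 to compound 4 changes both the substituent and its place on the phenyl ring, so the compounds shown do not tell which of the two matters. On these data alone, a 2-chlorophenyl or 3-methylphenyl group on the same carbon would separate them, and it remains open how either would read with the cyclobutyl amine of compound 1.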